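Para-fluoro on the benzamide of a cytosine-bearing amide

This account rests on a few compounds, and the source may have more. Where it says the series, first, only, none or still open, it means among the compounds named here.

The study measures growth inhibition in a functional assay on SK-BR-3 cells (Homo sapiens) for cytotoxicity, read by MTT assay, with a stated time of 72 h (on this read-out higher numbers stand for weaker inhibition and lower numbers for stronger inhibition), for a small set of amides built on the core of compound 1 `Nc1ccn(C/C=C\CNC(=O)c2ccccc2)c(=O)n1`. In this assay compound 1 gives 72000 nM, the only number that is shown among the values in hand. Compound 2 `Cc1cn(C/C=C\CNC(=O)c2ccc(F)cc2)c(=O)[nH]c1=O` carries a different core and gives > 100000 nM, which is a limit of the assay rather than a number (the limit of > 100000 nM in this assay, at which 1 of the 2 values shown sits). Compound 3 `Nc1ccn(C/C=C\CNC(=O)c2ccc(F)cc2)c(=O)n1` has not yet been measured; it differs from compound 1 only by fluoro in place of hydrogen on an aromatic carbon. For the measured compounds named here, no measured pair shows this change, so no direction can be read from the data. Compound 3 is therefore expected to lie close to compound 1, at an estimated 70000 nM with a range from 30000 nM to 160000 nM, with the step of a 1.0-fold lower number from compound 1 to compound 3 (0.01 log units; within the scatter) expected to stay within the usual scatter.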

Compound 3, half-maximal inhibitory concentration: > 100000 nM
Compound 3 gave a limit, no number (the forecaster's own chance of this, stated with the estimate: 35%); middle value at least 1.4-fold (0.15 log units) away from the limit.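

Phenyl to 4-fluorophenyl can now be read directly on the shared core in this assay, as an at least 1.3-fold higher number from compound 1 to compound 3 (0.14 log units; that floor lies within the scatter). On these data alone, the value of compound 3 is a limit of the assay and not a number, so the step gives only a floor; that floor stays within the usual scatter, and the true size of the change remains unknown. The step does show that fluoro at this position, para to a large group, brings no stronger inhibition, and compound 3 joins the values that cannot be ranked against one another: the limit of > 100000 nM in this assay, at which 2 of the 3 values shown sit.

The compounds shown leave open whether chloro, methoxy or an amine at this position would give a lower number than compound 1. They also leave open whether a carboxylic acid on this ring would give a value that can be read as a number.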